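A trifluoromethoxy swap on a compound at the limit

A few compounds are considered here, and "the series" means these few. Any claim that something is new, unique, unknown or untested is made for them only; others in the source may bear on it.

Compound 1 `CCC(C)Oc1ccc(C(O)C2OC(=O)c3c(OC)cc(OC)cc32)cc1` gives > 40000 nM as a limit
Compound 2 `COCCCOc1ccc(C(O)C2OC(=O)c3c(OC)cc(OC)cc32)cc1` gives > 40000 nM as a limit
Compound 3 `COc1cc(OC)c2c(c1)C(C(O)c1ccc(OCCOc3ccccc3)cc1)OC2=O` gives > 40000 nM as a limit

In an ADME assay on RAW264.7 cells (Mus musculus) for cytotoxicity, read by MTT assay, with a stated time of 24 h, in the presence of a further agent that is not named here (on this read-out higher numbers stand for weaker inhibition and lower numbers for stronger inhibition), compound 3 gives > 40000 nM as a limit and not a number. The change to compound 4 `COc1cc(OC)c2c(c1)C(C(O)c1ccc(OCc3ccc(OC(F)(F)F)cc3)cc1)OC2=O` is 4-(trifluoromethoxy)phenyl in place of phenoxymethyl on a saturated chain carbon bound to an oxygen on an aromatic ring and it sits on a saturated chain carbon bound to an oxygen on an aromatic ring. Two measured changes in this part of the molecule bear on it, a step that the two limits leave unreadable from compound 1 to compound 3 and a step that the two limits leave unreadable from compound 2 to compound 3 and neither has a readable size. The record is the limit of > 40000 nM in this assay, at which 3 of the 3 values shown sit, so it shows no direction. No shift beyond the scatter is therefore expected, and the expected step is a number no higher from compound 3 to compound 4 (the limit leaves the size open) in either direction. For compound 4 the estimated value is 40000 nM with an expected range from 20000 nM to 80000 nM and a reading as a limit is likely.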

Compound 4, half-maximal inhibitory concentration: > 40000 nM
Compound 4 was reported as a limit; the forecaster's own chance of this, stated with the estimate: 80%; the middle value sits exactly at the limit.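

No step from compound 2 or compound 3 to compound 4 can be read, because each of these compounds is reported only as a limit: the limit of > 40000 nM in this assay, at which 4 of the 4 values shown sit.

The compounds shown leave open whether these groups on the shared core differ at all in this assay.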